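Cytotoxicity in the anilino-cyanophenyl series: aryl swaps

The source may report more compounds than this note shows. Statements on the series, on what has been measured and on what is new or still open speak of the compounds shown alone.

Two compounds of the series carry a cytotoxicity number. Compound 1 `Cc1cc(-c2ccc(F)cc2)cc(C)c1Nc1ccnc(Nc2ccc(C#N)cc2)n1` and compound 2 `Cc1cc(-c2ccccc2C(F)(F)F)cc(C)c1Nc1ccnc(Nc2ccc(C#N)cc2)n1` share the core and differ only in the aryl group attached to an aromatic carbon. In an ADME assay on MT4 cells (Homo sapiens) for cytotoxicity, read by MTT assay, with a stated time of 4 days (on this read-out higher numbers stand for lower toxicity in this test and lower numbers for higher toxicity in this test), compound 1 gives 4170 nM, and compound 2 gives 4210 nM. The step of a 1.0-fold higher number from compound 1 to compound 2 (0.00 log units; within the scatter) shows that exchanging the aryl group left the read-out unchanged. Compound 2 thus stands at the higher of the two numbers, but within the scatter of compound 1.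

Compound 3 `Cc1cc(-c2c(C)cccc2C)cc(C)c1Nc1ccnc(Nc2ccc(C#N)cc2)n1` is the next member: 2,6-dimethylphenyl in place of 2-(trifluoromethyl)phenyl on an aromatic carbon. For the measured compounds named here, the only step that bears on it is the aryl exchange from compound 1 to compound 2, which produced no shift beyond the scatter. The expectation for this assay is therefore no step beyond the scatter, a 1.0-fold lower number from compound 2 to compound 3 (0.00 log units; within the scatter), in either direction. Compound 3 is estimated at 4200 nM, with a range from 1900 nM to 9500 nM.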

Compound 3, half-maximal cytotoxic concentration: 2590 nM
Beside the measured number, compound 3's estimate is 1.6-fold (0.21 log units) above it, within the range that was stated.
By their numbers in this assay, from the lowest: compounds 3, 1 and 2 (each within the scatter of the next).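

Notes on this position: the exchange of 2-(trifluoromethyl)phenyl for 2,6-dimethylphenyl gives a 1.6-fold lower number from compound 2 to compound 3 (0.21 log units; within the scatter) in this assay, and the exchange of 4-fluorophenyl for the same group gives a 1.6-fold lower number from compound 1 to compound 3 (0.21 log units; within the scatter). The group on this aromatic carbon can therefore be free of fluorine, with 8 heavy atoms, all carbon, and the read-out for compounds 1, 2 and 3 still stays within the scatter across all three pairs. No measurement at hand speaks to what lies behind this flat read-out.

All three groups are substituted phenyl rings without hydrogen-bond donors or acceptors, so this flat picture holds for compounds 1, 2 and 3 only. As far as these compounds go, whether an amine, a carboxylic acid or a longer alkyl chain at this place would give a step beyond the scatter remains open.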